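From ethyl to cyclopropyl on an aromatic nitrogen

The compounds below may be only part of what the source reports. "The series", "measured", "known", "first", "only" and "open" are said of these compounds alone.

Measured in a physicochemical assay for lipophilicity, at pH 7.4; on this read-out higher numbers stand for higher lipophilicity and lower numbers for lower lipophilicity:
- compound 1 `CCn1nc(CC(=O)Nc2ccc(OC(F)(F)F)c(Cl)c2)c2ccccc2c1=O` reads 5.42
- compound 2 `O=C(O)Cn1nc(Cc2cn3cc(OCC4CC4)c(Cl)cc3n2)c2ccccc2c1=O` reads 2.27

Of these two numbers, the higher belongs to compound 1 at 5.42 in this assay, while compound 2 at 2.27 lies lower by a gap well beyond the scatter. The two compounds differ in more than one place, so that gap cannot be tied to any single structural change.

The compound awaiting measurement is compound 3 `O=C(Cc1nn(C2CC2)c(=O)c2ccccc12)Nc1ccc(OC(F)(F)F)c(Cl)c1`, which matches compound 1 except at one site. It carries cyclopropyl in place of ethyl on an aromatic nitrogen and is otherwise unchanged. Among the compounds with values here, no measured pair shows this swap, so the expectation rests on the structural change alone, starting from compound 1 at 5.42 as the reference. In this assay, no step beyond the scatter is expected, with only a slight lean towards a lower number. The expected size is a number 0.12 log units lower from compound 1 to compound 3 (within the scatter) in this estimate. For compound 3 the expected value is 5.3 with an estimated range from 4.9 to 5.7 in this assay.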

Compound 3, distribution coefficient: 5.43
Estimate against measurement, compound 3: 0.13 log units below; low and high end bracket the measured number.
By their numbers in this assay, from the lowest: compound 2; then compounds 1 and 3 (each within the scatter of the next).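

In this assay, within the data shown here, cyclopropyl in place of ethyl on an aromatic nitrogen gives a number 0.01 log units higher from compound 1 to compound 3 (within the scatter), and this is the first comparison in the set that isolates a single site. At this position next to the ring nitrogen, the change from ethyl to cyclopropyl adds one carbon and a three-membered ring, yet compound 1 and compound 3 remain within the scatter of each other, so this swap gives no measurable shift in this read-out and the two cannot be ranked. No measured evidence on this position or this change is available to explain the result.

The compounds shown leave open whether the read-out would stay as flat with a longer chain such as n-butyl, or with an amine carried on this nitrogen, as only ethyl and cyclopropyl can be compared here on the core of compound 1. From the compounds shown here alone, it also remains open how much of the wide gap between compound 2 and the other two compounds belongs to this site, as compound 2 differs from them in more than one place.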